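Working notes: shortening the protected chain of compound 2

The source may report more compounds than this note shows. Statements on the series, on what has been measured and on what is new or still open speak of the compounds shown alone.

Compound 1 (`O=C(O)COn1nnc2ccccc21`): > 100000 nM (a limit of the assay)
Compound 2 (`CC(C)(C)OC(=O)NCCCN(CCCCN(CCCNC(=O)COn1nnc2ccccc21)C(=O)OC(C)(C)C)C(=O)OC(C)(C)C`): 37400 nM

Going by the values given here, in a toxicity assay (RAW264.7 cells) for inhibition, with Mus musculus as the target, read by resazurin assay, with a stated time of 72 h (a lower number here means that less compound is tolerated, a higher number that more compound is tolerated), compound 2 gives 37400 nM as the only actual number so far. Compound 1 reaches only a limit of the assay (> 100000 nM).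

Compound 3 (`CC(C)(C)OC(=O)NCCCCN(CCCNC(=O)COn1nnc2ccccc21)C(=O)OC(C)(C)C`) carries hydrogen in place of 3-((tert-butoxycarbonyl)amino)propyl on an amide-type nitrogen. Among the compounds with values here, no measured step covers this change, so the expectation is loose. A small step toward more compound tolerated is expected (a 1.4-fold higher number from compound 2 to compound 3 (0.14 log units; within the scatter)), not clearly beyond the usual scatter. The direction leans only on the fact that compound 1, without the protected chain, sits at its limit (> 100000 nM). The half-maximal cytotoxic concentration of compound 3 is estimated at 52000 nM, with an expected range from 20000 nM to 100000 nM in this assay.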

Compound 3, half-maximal cytotoxic concentration: > 100000 nM
Compound 3 was reported as a limit; the forecaster's own chance of this, stated with the estimate: 20%; at least 1.9-fold (0.28 log units) between middle value and limit.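

Going by these compounds alone, this is the first step that differs in one place: hydrogen in place of 3-((tert-butoxycarbonyl)amino)propyl on an amide-type nitrogen gives an at least 2.6-fold higher number from compound 2 to compound 3 (0.42 log units; beyond the scatter) in this assay, so the change at this nitrogen alone moves the number beyond the scatter. Compound 3 gives > 100000 nM, which is a limit of the assay and not a number. The step is therefore only a lower bound, and its full size cannot be read: the limit of > 100000 nM in this assay, at which 2 of the 3 values shown sit.

Open, going by these compounds, is whether a free amine or a methyl group on the same amide-type nitrogen would give a number closer to compound 2 or also reach the limit. Also open, on these data alone, is whether a longer chain there would give a lower number than compound 2.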